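The source may report more compounds than this note shows. Statements on the series, on what has been measured and on what is new or still open speak of the compounds shown alone.

Measured compounds in the series:
- compound 1, `CCOC(=O)c1sc(NC(=O)Cn2cc(-c3ccc(OC)cc3)nn2)nc1C`: 2330 nM
- compound 2, `COc1ccc(-c2cn(CC(=O)Nc3cc(C)on3)nn2)cc1`: > 30000 nM
- compound 3, `Cc1cc(NC(=O)Cn2cc(-c3ccc([N+](=O)[O-])cc3)nn2)no1`: 1220 nM

All three were run in a functional assay on BMDM cells (Mus musculus, strain C57BL/6) for inhibition, with a stated time of 2 days; on this read-out higher numbers stand for weaker inhibition and lower numbers for stronger inhibition. The value of compound 2 is a limit of the assay and not a number, (the limit of > 30000 nM in this assay, at which 1 of the 3 values shown sits). Compound 1 and compound 2 carry different cores; how the two cores differ is not broken down here. Compound 2 and compound 3 share a core and differ in one place, (nitro in place of methoxy on an aromatic carbon), and that change gave an at least 24-fold lower number from compound 2 to compound 3 (1.39 log units; beyond the scatter). The values of compound 1 and compound 3 sit within the usual scatter of each other, so no order between them is drawn.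

Compound 4, `CCOC(=O)c1sc(NC(=O)Cn2cc(-c3ccc([N+](=O)[O-])cc3)nn2)nc1C`, is not yet measured in this assay. It stands to compound 1 as compound 3 stands to compound 2: the change is nitro in place of methoxy on an aromatic carbon, and the place given for it reads the same as for the earlier pair, so the two changes are the same. Among the measured compounds shown here, only one measured instance exists, and it starts from a limit, so its true size is open. Beside the earlier step, compound 4 is expected to show a 3.9-fold lower number from compound 1 to compound 4 (0.59 log units; beyond the scatter), a smaller step than the measured one. For the measured compounds named here, that expectation rests on the value of compound 1, 2330 nM, and on the single measured pair. The estimate for compound 4 in this assay is 600 nM, expected to fall between 150 nM and 2000 nM.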

Compound 4, half-maximal inhibitory concentration: 1840 nM
For compound 4 the middle estimate is 3.1-fold (0.49 log units) below the measured one, and the stated range covers the measured number.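

In this assay, the change from 4-methoxyphenyl to 4-nitrophenyl on the core of compound 1 gives a 1.3-fold lower number from compound 1 to compound 4 (0.10 log units; within the scatter), so the large step seen on the core of compound 2 does not reappear here. The change therefore does not carry over between these two cores at a constant size, although one pair on each core cannot show which part of the cores decides the outcome: the same change on two cores in this assay, an at least 24-fold lower number (1.39 log units; beyond the scatter) from compound 2 to compound 3 and a 1.3-fold lower number (0.10 log units; within the scatter) from compound 1 to compound 4, at least 19-fold (1.28 log units) apart, beyond the scatter of two such steps. The value of compound 2 is a limit of the assay and not a number, so the true size of the step on that core remains unknown, and only its lower bound can be read: the limit of > 30000 nM in this assay, at which 1 of the 4 values shown sits.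

On these data alone, it remains open whether an amine or a carboxylic acid in place of the methoxy, on the same aromatic carbon, would follow the step on the core of compound 1 or the one on the core of compound 2. As far as these compounds go, it is also open how the change from methoxy to nitro reads on a third core, which would show whether either of the two steps is typical of the series.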